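The compounds below may be only part of what the source reports. "The series", "measured", "known", "first", "only" and "open" are said of these compounds alone.

Among the compounds with values here, compound 1 `O=C1c2ccccc2OCC1Cc1ccc(O)cc1` gives 20100 nM in a functional assay on BT-549 cells (Homo sapiens) for cytotoxicity, read by MTT assay, with a stated time of 24 h (a higher number here means a weaker inhibitor, a lower number a stronger inhibitor), the lowest of the two numbers measured so far. Compound 2 `Cc1ccc(CC2COc3ccccc3C2=O)cc1` gives 42200 nM, and the step is a 2.1-fold higher number from compound 1 to compound 2 (0.32 log units; beyond the scatter) for methyl in place of hydroxy on an aromatic carbon. Compound 3 `Cc1ccc2c(c1)OCC(Cc1ccc(O)cc1)C2=O` differs from compound 1 in one place: methyl in place of hydrogen on an aromatic carbon. Within the data shown here, the only measured step concerns a different change at a different place, so it bears only loosely on this one; the step from compound 1 to compound 3 in this assay is expected to stay within the scatter, a 1.0-fold lower number from compound 1 to compound 3 (0.00 log units; within the scatter). Compound 3 is therefore estimated at 20000 nM, within a range from 8000 nM to 50000 nM.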

Compound 3, half-maximal inhibitory concentration: 28700 nM
Estimate against measurement, compound 3: 1.4-fold (0.16 log units) below; the measured number falls inside the stated range.
By their numbers in this assay, from the lowest: compounds 1, 3 and 2 (each within the scatter of the next, the first and the last beyond it).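

In this assay, placing methyl on an aromatic carbon of the fused system of the shared core, meta to a fused ring and para to a fused ring, gives a 1.4-fold higher number from compound 1 to compound 3 (0.15 log units; within the scatter). This is the first change shown on that ring, and at this place a single methyl leaves the number within the scatter. No evidence on hand accounts for this result. The compounds shown leave open whether a methoxy group, a chlorine atom or an amine at this carbon would move the number beyond the scatter, and whether methyl at the other carbons of this ring would behave alike.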